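Swapping an acid-bearing indole for an azaindole in compound 1

The source may report more compounds than this note shows. Statements on the series, on what has been measured and on what is new or still open speak of the compounds shown alone.

Of the compounds shown here, three built on the same core have been tested in a functional assay on DU-145 cells (Homo sapiens) for inhibition, read by trypan blue exclusion, with a stated time of 72 h; a higher number here means a weaker inhibitor, a lower number a stronger inhibitor. Compound 1 `Cn1c(=O)c(S(=O)(=O)c2ccc(F)cc2F)cc2cnc(Nc3ccc4[nH]c(C(=O)O)cc4c3)nc21` gives 10000 nM, the highest number of the three. Compound 2 `CN1CCN(c2ccc(Nc3ncc4cc(S(=O)(=O)c5ccc(F)cc5F)c(=O)n(C)c4n3)cc2)CC1` gives 5000 nM, which lies within the usual scatter of that of compound 1. Compound 3 `COc1ccc(S(=O)(=O)c2cc3cnc(Nc4ccc5[nH]ccc5c4)nc3n(C)c2=O)cc1` gives 500 nM, a number well apart from that of compound 1 and beyond the scatter.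

The new compound 4 `Cn1c(=O)c(S(=O)(=O)c2ccc(F)cc2F)cc2cnc(Nc3cnc4[nH]ccc4c3)nc21` differs from compound 1 in one place: a group of 9 heavy atoms (7 carbon, 2 nitrogen; one five-membered aromatic ring with 1 hetero atom, one six-membered aromatic ring with 1 hetero atom) in place of a group of 12 heavy atoms (9 carbon, 1 nitrogen, 2 oxygen; one five-membered aromatic ring with 1 hetero atom, one six-membered aromatic ring of carbon only), on a nitrogen on an aromatic ring. Compound 3, which also carries no carboxy group on its two-ring nitrogen substituent, shows a much lower number than compound 1, so compound 4 is expected to move in the same direction. The other part of compound 3 differs from that of compound 4, though, so the full extent of that gap is not expected.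

For compound 4 a step of a 6.7-fold lower number from compound 1 to compound 4 (0.82 log units; beyond the scatter) is expected, toward stronger inhibition and beyond the scatter, with an estimated value of 1500 nM and a likely range from 400 nM to 6000 nM.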

Compound 4, half-maximal inhibitory concentration: 750 nM
Estimate against measurement, compound 4: 2.0-fold (0.30 log units) above; measured number inside the range.
By their numbers in this assay, from the lowest: compounds 3 and 4 (each within the scatter of the next); then compounds 2 and 1 (each within the scatter of the next).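

In this assay, this swap gives a 13-fold lower number from compound 1 to compound 4 (1.12 log units; beyond the scatter), a large step and the first one here between two compounds that differ in only one place, so it shows that the group on this nitrogen on an aromatic ring strongly affects the number while the rest of the molecule stays fixed. Two things change together in this step: the carboxy group is lost, and the six-membered aromatic ring gains a hetero atom, so the step cannot be divided between them. Nothing measured here explains why the number falls.

The compounds shown leave open which of the two changes matters more, and a 1H-indol-5-yl group without the carboxy group on this same core would help separate them. Also open, on these data alone, is how a methyl ester or a primary amide in place of the carboxylic acid would behave.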